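A few compounds are considered here, and "the series" means these few. Any claim that something is new, unique, unknown or untested is made for them only; others in the source may bear on it.

Measured compounds: compound 1 `COc1cc(OC)c2c(=O)cc(-c3ccc(OCCBr)cc3)oc2c1`; compound 2 `COc1cc(OC)c2c(=O)cc(-c3ccc(OCCN4CCCC4=O)cc3)oc2c1`; compound 3 `COc1cc(OC)c2c(=O)cc(-c3ccc(OC4CCNCC4)cc3)oc2c1`.

In a functional assay (Homo sapiens) for antiproliferative activity, read by resazurin assay, with a stated time of 48 h, tested at 20 uM (on this read-out lower numbers stand for a weaker effect and higher numbers for a stronger effect at the one concentration tested), compound 1 gives 20% and compound 2 gives 33%. Among the measured compounds shown here, the only measured step is a number 13 percentage points higher from compound 1 to compound 2 (beyond the scatter). For compound 3 the result in this assay is "not determined" (no result reported), so on the numbers shown it stands nowhere. Compound 4 `COc1cc(OC)c2c(=O)cc(-c3ccc(OCCN)cc3)oc2c1` differs from compound 3 by 2-aminoethyl in place of piperidin-4-yl on an oxygen on an aromatic ring. For the measured compounds named here, no measured step bears directly on this change: the one step available concerns a different group further out on the chain, and it was modest. With no anchor value for compound 3, neither size nor direction of the step in this assay can be set, and only the spread between compound 1 and compound 2 serves as a guide. Compound 4 is therefore expected to give 28%, with a range from 10% to 50%.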

Compound 4, a percentage reported as inhibition, at one concentration (the size of the read-out at that concentration, not a potency): 70%
Compound 4: middle estimate off by 42 percentage points, on the low side; measured number outside the range, above it.
By their numbers in this assay, from the lowest: compound 1; then compound 2; then compound 4.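

In this assay, the group at the end of the chain matters far more than the earlier step showed: amino in place of 2-oxopyrrolidin-1-yl gives a number 37 percentage points higher from compound 2 to compound 4 (beyond the scatter), and amino in place of bromo gives a number 50 percentage points higher from compound 1 to compound 4 (beyond the scatter). A free amino group on this chain therefore sets compound 4 clearly apart from both neutral-ended chain compounds shown. Nothing available accounts for this gain.

The step from compound 3 to compound 4 cannot be read, so piperidin-4-yl against 2-aminoethyl remains unsettled. Also open, on these data alone, is whether dimethylamino on the same chain, or a longer 3-aminopropyl chain, keeps this level.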